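The source may report more compounds than this note shows. Statements on the series, on what has been measured and on what is new or still open speak of the compounds shown alone.

Measured compounds and values:
- compound 1 `COc1cccc2c(=O)cc(/C=C/[S+](C)[O-])oc12`: 9000 nM
- compound 2 `CC(C)C(=O)Oc1ccc2oc(/C=C/[S+](C)[O-])cc(=O)c2c1`: 9100 nM
- compound 3 `CC(C)COc1ccc2oc(/C=C/[S+](C)[O-])cc(=O)c2c1`: 5000 nM

All three numbers come from a functional assay on DLD-1 cells (Homo sapiens) for cytotoxicity, with a stated time of 48 h; a higher number here means a weaker inhibitor, a lower number a stronger inhibitor. Compound 2 holds the highest of the three, yet nothing sets it apart: compound 1 gives 9000 nM, the same number within the scatter, and compound 3 gives 5000 nM, which is also within the scatter of compound 2. Within the data shown here, the one step recorded at the shared oxygen, a 1.8-fold lower number from compound 2 to compound 3 (0.26 log units; within the scatter), exchanges the isopropylcarbonyl for an isobutyl and does not leave the scatter.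

Compound 4 `CC(=O)Oc1ccc2oc(/C=C/[S+](C)[O-])cc(=O)c2c1` is not yet measured in this assay. It differs from compound 2 by methyl in place of isopropyl on a carbonyl carbon. Among the measured compounds shown here, no measured pair trims an acyl chain while keeping the ester, so the only step that bears on it is the one from compound 2 to compound 3, which changes the same oxygen substituent more deeply and still stays within the scatter. On that basis no step beyond the scatter is expected for a 1.0-fold lower number from compound 2 to compound 4 (0.00 log units; within the scatter).

Compound 4 is therefore expected to give about 9000 nM in this assay, estimated within 4000 nM to 20000 nM.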

Compound 4, half-maximal inhibitory concentration: > 10000 nM
Compound 4 was reported as a limit; the forecaster's own chance of this, stated with the estimate: 10%; middle value at least 1.1-fold (0.04 log units) away from the limit.
By their numbers in this assay, from the lowest: compounds 3, 1 and 2 (each within the scatter of the next). At a limit, above all of these: compound 4.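

In this assay, compound 4 is reported only as a limit and not as a number: the limit of > 10000 nM in this assay, at which 1 of the 4 values shown sits. Methyl in place of isopropyl on the carbonyl carbon gives an at least 1.0-fold higher number from compound 2 to compound 4 (0.04 log units; that floor lies within the scatter), and acetyl in place of isobutyl on the oxygen gives an at least 2.0-fold higher number from compound 3 to compound 4 (0.30 log units; that floor lies within the scatter); each is only a floor, so neither step is shown to leave the scatter, and neither is shown to stay within it. Among these compounds, this is the first change at this position that keeps the ester, and it adds what the earlier compounds did not show: a substituent on this oxygen, here acetyl, whose reading has an open upper side, whereas the step from isopropylcarbonyl to isobutyl had a closed reading within the scatter.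

As far as these compounds go, how far compound 4 really lies from compound 2 and compound 3 stays open, so no dependence on acyl chain size can be claimed from this pair. Also open, from the compounds shown here alone, is how a longer acyl chain such as hexanoyl, or an ester chain ending in an amine or a carboxylic acid, would read at the same oxygen in this assay.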